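The source may hold more compounds than are shown below. What is called first, only, known or untested is meant among the compounds shown, and "the series" means these compounds.

Compound 1 `C=CCON/C(=N\C1=NC(=O)C(=O)N1C(C)C)Nc1ccc(Cl)c(Cl)c1` and compound 2 `CCCCCCN/C(=N\C1=NC(=O)C(=O)N1C(C)C)Nc1ccc(Cl)c(Cl)c1` are the measured pair.

In an in vitro ADME assay on microsomes from liver (Mus musculus) for metabolic stability, read by LC-MS (on this read-out lower numbers stand for a shorter-lived compound and higher numbers for a longer-lived compound), compound 1 gives only a limit, > 1 h. Compound 1 sits at that limit (the limit of > 1 h in this assay, at which 1 of the 2 values shown sits). In this assay compound 2 gives 0.579 h, the only number shown, so compound 2 stands as the single measured point. For the measured compounds named here, the step of an at least 1.7-fold lower number from compound 1 to compound 2 (0.23 log units; that floor lies within the scatter) is the only measured step and changes a different position, so it bears little on the change to compound 3 `CC(C)N1C(=O)C(=O)N=C1/N=C(\NCCCN(C)C)Nc1ccc(Cl)c(Cl)c1`, which is dimethylamino in place of propyl on a saturated chain carbon, three bonds along the chain from an amine nitrogen. Going by the values given here, no measured step speaks to that exchange, so no change beyond the scatter is expected, and compound 3 is expected at 0.8 h (range 0.3 h to 2.5 h), meaning a step of a 1.4-fold higher number from compound 2 to compound 3 (0.14 log units; within the scatter) that is estimated rather than known.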

Compound 3, half-life: > 1 h
Compound 3: only a limit was reported (the forecaster's own chance of this, stated with the estimate: 25%); middle value at least 1.2-fold (0.09 log units) from the limit.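

In this assay compound 3 gives only a limit, > 1 h. Dimethylamino in place of propyl on a saturated chain carbon, three bonds along the chain from an amine nitrogen, gives an at least 1.7-fold higher number from compound 2 to compound 3 (0.23 log units; that floor lies within the scatter), the first measured reading for this position, and its floor does not clear the scatter. The step between compound 1 and compound 3 cannot be read, as both values sit at the same limit: the limit of > 1 h in this assay, at which 2 of the 3 values shown sit.

Going by these compounds, the true half-life of compound 3 remains open. So does whether a piperidine or a carboxylic acid at the end of this chain would also reach the limit.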